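The source may hold more compounds than are shown below. What is called first, only, known or untested is meant among the compounds shown, and "the series" means these compounds.

Compound 1 `O=C(N/N=C/c1ccccc1)c1cccnc1Nc1cccc(C(F)(F)F)c1`: 21.2%
Compound 2 `O=C(N/N=C/c1ccc(O)cc1)c1cccnc1Nc1cccc(C(F)(F)F)c1`: 59.5%
Compound 3 `COc1cccc(/C=N/NC(=O)c2cccnc2Nc2cccc(C(F)(F)F)c2)c1`: 30.3%

All three were measured in a functional assay on the whole organism (strain Wistar) for inhibition, with Rattus norvegicus as the target, read by paw edema, with a stated time of 3 h, at a dose of 10 mg/kg by the intraperitoneal route; on this read-out higher numbers stand for more inhibition at the one dose given (going by the name of the read-out) and lower numbers for less inhibition. Compound 3 stands second highest of the three: it sits nearest to compound 1, as the step of a number 9.1 percentage points higher from compound 1 to compound 3 (within the scatter) shows, and furthest from compound 2, since a number 29.2 percentage points lower from compound 2 to compound 3 (beyond the scatter).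

Compound 4 `CN(C)c1ccc(/C=N/NC(=O)c2cccnc2Nc2cccc(C(F)(F)F)c2)cc1` has not yet been measured. Compared with compound 3 it shows (4-(dimethylamino)phenyl in place of 3-methoxyphenyl on a carbon with a double bond to nitrogen). Within the data shown here, two measured steps bear on this change. Putting a hydroxy group onto the ring that hangs on the carbon double-bonded to nitrogen gave a number 38.3 percentage points higher from compound 1 to compound 2 (beyond the scatter), whereas a methoxy group on that ring gave only a number 9.1 percentage points higher from compound 1 to compound 3 (within the scatter). Swapping the 4-hydroxyphenyl ring for a 3-methoxyphenyl ring gave a number 29.2 percentage points lower from compound 2 to compound 3 (beyond the scatter). A 4-(dimethylamino)phenyl ring shares the substitution pattern of compound 2 but brings no hydrogen-bond donor, so a modest rise beyond the scatter is expected, not a return to the level of compound 2.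

Compound 4 is therefore estimated at 42%, within a range of 22% to 62%, meaning an expected step of a number 11.7 percentage points higher from compound 3 to compound 4 (beyond the scatter).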

Compound 4, a percentage reported as inhibition, in the whole organism at one dose (the size of the read-out at that dose, not a potency): 39.5%
For compound 4 the middle estimate is 2.5 percentage points above the measured one, within the range that was stated.
By their numbers in this assay, from the lowest: compounds 1, 3 and 4 (each within the scatter of the next, the first and the last beyond it); then compound 2.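

In this assay a group other than hydroxy can also carry the number past the scatter, for dimethylamino in place of hydrogen gives a number 18.3 percentage points higher from compound 1 to compound 4 (beyond the scatter) on the ring, which the methoxy group of compound 3 did not do. Even so, dimethylamino in place of hydroxy gives a number 20 percentage points lower from compound 2 to compound 4 (beyond the scatter) at this position, and the change of ring itself gives a number 9.2 percentage points higher from compound 3 to compound 4 (within the scatter) so that 4-(dimethylamino)phenyl and 3-methoxyphenyl cannot be told apart on this read-out. Nothing at hand explains these differences.

A 3-hydroxyphenyl or 4-methoxyphenyl ring would help to show whether the hydroxy group itself or the place it occupies on the ring matters more for compound 2. On these data alone, how a 4-aminophenyl ring, with its free amine, or a ring bearing a carboxylic acid would read also remains open.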